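The source may hold more compounds than are shown below. What is called first, only, known or untested is meant among the compounds shown, and "the series" means these compounds.

Measured so far in a functional assay on U-87MG ATCC cells for inhibition, with U-87 MG (Homo sapiens) as the target, read by MTT assay, with a stated time of 72 h; on this read-out lower numbers stand for stronger inhibition and higher numbers for weaker inhibition:

compound 1 `CCc1ccc(C(Nc2ccccn2)c2ccc3cccnc3c2O)cc1`, 9300 nM
compound 2 `CCc1ccc(C(Nc2cc(C)ccn2)c2ccc3cccnc3c2O)cc1`, 8900 nM
compound 3 `Oc1c(C(c2ccc3c(c2)CCC3)N2CCCCC2)ccc2ccoc12`, 5000 nM

Compound 1 gives the highest of the three numbers in this assay , though its gaps to the other two stay within the scatter: compound 2 lies closest, and compound 3 furthest, and neither gap is beyond the scatter. Among the measured compounds shown here, the one measured step, a 1.0-fold lower number from compound 1 to compound 2 (0.02 log units; within the scatter), is within the scatter.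

Compound 4 `Oc1c(C(Nc2ccccn2)c2ccccc2F)ccc2cccnc12` differs from compound 1 in one place: 2-fluorophenyl in place of 4-ethylphenyl on a saturated chain carbon bound to an aromatic carbon and a nitrogen on an aromatic ring. For the measured compounds named here, no measured step touches this part of the structure; the only step on record, methyl in place of hydrogen on an aromatic carbon, is elsewhere and was within the scatter. With nothing to suggest movement, compound 4 is expected to sit close to compound 1, giving a 1.0-fold higher number from compound 1 to compound 4 (0.01 log units; within the scatter), a step not beyond the scatter. The estimate for compound 4 in this assay is therefore 9500 nM, with a range of 3000 nM to 30000 nM.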

Compound 4, half-maximal inhibitory concentration: > 10000 nM
Compound 4 ended at the assay's limit; the forecaster's own chance of this, stated with the estimate: 15%; at least 1.0-fold (0.02 log units) between middle value and limit.
By their numbers in this assay, from the lowest: compounds 3, 2 and 1 (each within the scatter of the next). At a limit, above all of these: compound 4.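

In this assay compound 4 reads > 10000 nM, which is a limit of the assay and not a number. This is the first change shown at this position, on a saturated chain carbon bound to an aromatic carbon and a nitrogen on an aromatic ring, and 2-fluorophenyl in place of 4-ethylphenyl gives no sign of stronger inhibition, with an at least 1.0-fold higher number from compound 1 to compound 4 (0.03 log units; that floor lies within the scatter). That step is only a floor, so how far the two compounds truly lie apart cannot be told, and the reading rests on a single capped value: the limit of > 10000 nM in this assay, at which 1 of the 4 values shown sits.

As far as these compounds go, compound 4 removes the ethyl and adds the fluorine in one step, and the effect of each alone stays open. A plain phenyl, or an amine or a carboxylic acid on that ring, would show whether this position can move the number in either direction.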